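Working notes: bromo in place of chloro

This account rests on a few compounds, and the source may have more. Where it says the series, first, only, none or still open, it means among the compounds named here.

Going by the values given here, in a functional assay on QGY-7703 cells (Homo sapiens) for cytotoxicity, read by MTT assay, with a stated time of 24 h (on this read-out higher numbers stand for weaker inhibition and lower numbers for stronger inhibition), compound 1 (`O=C1/C(=C/c2cccnc2)CN(S(=O)(=O)c2ccc(Br)cc2)C/C1=C\c1ccccc1F`) gives 12800 nM and compound 2 (`O=C1/C(=C/c2cccnc2)CN(S(=O)(=O)c2ccc(Cl)cc2)C/C1=C\c1ccccc1C(F)(F)F`) gives 3440 nM as the lower of only two numbers. The gap between these two values lies beyond the scatter, so compound 2 stands as the stronger inhibitor of the pair.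

Compound 3 (`O=C1/C(=C/c2cccnc2)CN(S(=O)(=O)c2ccc(Br)cc2)C/C1=C\c1ccccc1C(F)(F)F`) is compound 2 with bromo in place of chloro on an aromatic carbon, para to a large group, so that 4-chlorophenyl becomes 4-bromophenyl: bromo in place of chloro on an aromatic carbon is the whole difference. The (4-bromophenyl)sulfonyl form is otherwise unchanged from the (4-chlorophenyl)sulfonyl form.

Among the compounds with values here, no two measured compounds differ in one place only, so the data hold no direct step for this change. The expectation therefore rests on compound 2 at 3440 nM alone, and the range is kept wide. No shift beyond the scatter is expected in this assay and no firm direction can be given. The expected size is a 1.1-fold higher number from compound 2 to compound 3 (0.03 log units; within the scatter) and this stays within the scatter. Compound 3 is estimated at 3700 nM (expected range 1800 nM to 7500 nM).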

Compound 3, half-maximal inhibitory concentration: 5510 nM
Compound 3: middle estimate off by 1.5-fold (0.17 log units), on the low side; the measured number falls inside the stated range.
By their numbers in this assay, from the lowest: compounds 2 and 3 (each within the scatter of the next); then compound 1.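

In this assay, bromo in place of chloro on an aromatic carbon, para to a large group, gives a 1.6-fold higher number from compound 2 to compound 3 (0.20 log units; within the scatter), so this first direct reading of the change separates 4-bromophenyl from 4-chlorophenyl by no more than the usual scatter. Going by these compounds alone, compound 3 also links the series at a second place: trifluoromethyl in place of fluoro on an aromatic carbon gives a 2.3-fold lower number from compound 1 to compound 3 (0.37 log units; beyond the scatter), and with the (4-bromophenyl)sulfonyl form held constant, this is the only single-place step that lies beyond the scatter. No measurement in hand bears on the reason for either step.

The compounds shown leave open whether values at the 4-position of the sulfonyl-bearing phenyl stay within the scatter once the halogen gives way to a methoxy group, an amine or a carboxylic acid. They also leave open whether trifluoromethyl in place of fluoro gives a step of similar size with 4-chlorophenyl in place of 4-bromophenyl.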